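Aryl variation on the acrylamide arm: toward compound 3

The source may hold more compounds than are shown below. What is called first, only, known or untested is meant among the compounds shown, and "the series" means these compounds.

Measured so far:
compound 1 `O=C(/C=C/c1ccc([N+](=O)[O-])cc1)Nc1cc2c(Nc3ccc(F)c(Cl)c3)ncnc2cc1O[C@H]1CCOC1` — 12000 nM
compound 2 `COc1ccc(OC)c(/C=C/C(=O)Nc2cc3c(Nc4ccc(F)c(Cl)c4)ncnc3cc2O[C@H]2CCOC2)c1` — 7300 nM

Going by the values given here, in a functional assay on A549 cells (Homo sapiens) for cytotoxicity, read by MTT assay, with a stated time of 72 h (on this read-out lower numbers stand for stronger inhibition and higher numbers for weaker inhibition), compound 2 gives the lowest of the two numbers, but the one measured step, a 1.6-fold lower number from compound 1 to compound 2 (0.22 log units; within the scatter), is within the scatter, so the two compounds cannot be ordered. Compound 3 `O=C(/C=C/c1ccccc1[N+](=O)[O-])Nc1cc2c(Nc3ccc(F)c(Cl)c3)ncnc2cc1O[C@H]1CCOC1` carries the change (2-nitrophenyl in place of 2,5-dimethoxyphenyl on a double-bonded chain carbon bound to a double-bonded chain carbon). Among the compounds with values here, the only step that bears on it is that from compound 1, where a nitrophenyl stood in the same place; no 2-nitrophenyl has been measured. Hence no step beyond the scatter is expected for compound 3, a 1.3-fold higher number from compound 2 to compound 3 (0.11 log units; within the scatter), and the estimate for compound 3 is 9500 nM in the range 4000 nM to 22000 nM.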

Compound 3, half-maximal inhibitory concentration: 8820 nM
Estimate against measurement, compound 3: 1.1-fold (0.03 log units) above, within the range that was stated.
By their numbers in this assay, from the lowest: compounds 2, 3 and 1 (each within the scatter of the next).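

In this assay, 2-nitrophenyl in place of 4-nitrophenyl leaves the compounds unseparated (a 1.4-fold lower number from compound 1 to compound 3 (0.13 log units; within the scatter)), and the same holds for 2-nitrophenyl in place of 2,5-dimethoxyphenyl (a 1.2-fold higher number from compound 2 to compound 3 (0.08 log units; within the scatter)). All three aryl groups on this double-bonded chain carbon therefore lie within the scatter of one another, whether the nitro group stands as in 2-nitrophenyl or as in 4-nitrophenyl. No measurement offered here accounts for this result. Still open, from the compounds shown here alone, is whether an amine or a carboxylic acid on the phenyl ring would give a step beyond the scatter, and whether replacing the phenyl ring with a longer chain would do so.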